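From Methylphenyl to Trifluoromethylphenyl on the Ring Nitrogen

The source may hold more compounds than are shown below. What is called first, only, known or untested is meant among the compounds shown, and "the series" means these compounds.

Compound 1, `Cc1cc(=O)n(-c2ccc(Br)cc2F)nc1C(=O)Nc1ccc(Oc2ncnc3c2ccn3C)cc1`, gives 27700 nM in a functional assay on MCF7 cells (Homo sapiens) for cytotoxicity, read by MTT assay, with a stated time of 72 h; on this read-out lower numbers stand for stronger inhibition and higher numbers for weaker inhibition.
Compound 2, `Cc1cc(=O)n(-c2cccc(F)c2)nc1C(=O)Nc1ccc(Oc2ncnc3c2ccn3C)cc1`, gives 30800 nM in this assay.
Compound 3, `Cc1ccc(-n2nc(C(=O)Nc3ccc(Oc4ncnc5c4ccn5C)cc3)c(C)cc2=O)cc1`, gives 10800 nM in this assay.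

All three share the same core and differ only in the aromatic group attached to the ring nitrogen. Compound 3, carrying a 4-methylphenyl group, has the lowest number of the three: the change is a 2.6-fold lower number from compound 1 to compound 3 (0.41 log units; beyond the scatter), and a 2.9-fold lower number from compound 2 to compound 3 (0.46 log units; beyond the scatter). Compounds 1 and 2, which carry a bromo-fluorophenyl and a fluorophenyl group, sit close together, as a 1.1-fold higher number from compound 1 to compound 2 (0.05 log units; within the scatter) shows.

Compound 4, `Cc1cc(=O)n(-c2ccccc2C(F)(F)F)nc1C(=O)Nc1ccc(Oc2ncnc3c2ccn3C)cc1`, has not yet been measured in this assay. It differs from compound 3 in one place: 2-(trifluoromethyl)phenyl in place of 4-methylphenyl on an aromatic nitrogen. The two measured steps that bear on this are those from the halogen-bearing phenyl groups of compound 1 and compound 2 to the methylphenyl of compound 3, both modest and both in the direction of a lower number for compound 3. Returning to a fluorine-bearing phenyl group is therefore expected to move the number back up by a similar modest step, a 2.2-fold higher number from compound 3 to compound 4 (0.35 log units; beyond the scatter). Compound 4 is estimated at 24000 nM, with a likely range from 9000 nM to 60000 nM.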

Compound 4, half-maximal inhibitory concentration: 7840 nM
Estimate against measurement, compound 4: 3.1-fold (0.49 log units) above, outside the stated range (below it).
By their numbers in this assay, from the lowest: compounds 4 and 3 (each within the scatter of the next); then compounds 1 and 2 (each within the scatter of the next).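

In this assay, replacing the 4-methylphenyl with the 2-(trifluoromethyl)phenyl gives a 1.4-fold lower number from compound 3 to compound 4 (0.14 log units; within the scatter), so this position tolerates the change without a measurable shift, even though the entering group has more heavy atoms and carries fluorine. The same group separates clearly from the other two halogen-bearing aromatic groups, with a 3.9-fold lower number from compound 2 to compound 4 (0.59 log units; beyond the scatter) and a 3.5-fold lower number from compound 1 to compound 4 (0.55 log units; beyond the scatter). Fluorine on the aromatic group therefore does not by itself place a compound at the higher numbers: compound 1 and compound 2 lie there, while compound 4, which also carries fluorine, goes against any such pattern and stays level with compound 3, and nothing measured here explains why the fluorine-bearing groups part this way.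

As far as these compounds go, all four compounds carry a substituted phenyl on the ring nitrogen, so it remains open whether a phenyl bearing an amine or a carboxylic acid would behave like any of them. From the compounds shown here alone, it is also open what a longer alkyl chain in place of the phenyl ring would do to the number in this assay.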